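The source may report more compounds than this note shows. Statements on the series, on what has been measured and on what is new or still open speak of the compounds shown alone.

The measured compounds:
Compound 1, `CCCC(=O)Nc1ccc(Oc2cccc(OC)c2)cc1`, in an assay on isolated protein for binding affinity to melatonin receptor type 1B (Homo sapiens) (a higher number here means a weaker inhibitor, a lower number a stronger inhibitor), compound 1 gives 0.75 nM.
Compound 2, `CCC(=O)Nc1ccc(Oc2cccc(OC)c2)cc1`, in this assay compound 2 gives 6.8 nM.
Compound 3, `C/C=C/C(=O)Nc1ccc(Oc2cccc(OC)c2)cc1`, in this assay compound 3 gives 2.1 nM.

Compound 3 holds the second highest of the three numbers: there is a 2.8-fold higher number from compound 1 to compound 3 (0.45 log units; beyond the scatter), while there is a 3.2-fold lower number from compound 2 to compound 3 (0.51 log units; beyond the scatter). Compound 4, `COCC(=O)Nc1ccc(Oc2cccc(OC)c2)cc1`, has not yet been measured. Its difference from compound 3 is methoxymethyl in place of prop-1-en-1-yl on a carbonyl carbon. The measured steps that touch this carbonyl substituent are a 2.8-fold higher number from compound 1 to compound 3 (0.45 log units; beyond the scatter), a 3.2-fold lower number from compound 2 to compound 3 (0.51 log units; beyond the scatter) and a 9.1-fold higher number from compound 1 to compound 2 (0.96 log units; beyond the scatter); each of them is modest, and all three show that changing this chain shifts the number beyond the scatter, with the shorter chain of compound 2 giving the highest number. For the measured compounds named here, no measured step brings an oxygen into this chain, so that part of the change has no precedent here. A modest rise in this assay is therefore expected for compound 4. Compound 4 is expected to give 10 nM in this assay, with a range from 2.5 nM to 40 nM. That estimate amounts to an expected 4.8-fold higher number from compound 3 to compound 4 (0.68 log units; beyond the scatter).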

Compound 4, inhibition constant: 5.9 nM
Compound 4: middle estimate off by 1.7-fold (0.23 log units), on the high side, within the range that was stated.
By their numbers in this assay, from the lowest: compound 1; then compound 3; then compounds 4 and 2 (each within the scatter of the next).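

In this assay, for the compounds shown here, the methoxymethyl chain gives the first reading of an oxygen at this position on the carbonyl carbon: there is a 1.2-fold lower number from compound 2 to compound 4 (0.06 log units; within the scatter), so methoxy in place of methyl leaves compound 4 level with compound 2. The oxygen-bearing chain does not match the two chains that give lower numbers, with a 2.8-fold higher number from compound 3 to compound 4 (0.45 log units; beyond the scatter) and a 7.9-fold higher number from compound 1 to compound 4 (0.90 log units; beyond the scatter), so among these compounds neither the prop-1-en-1-yl nor the propyl chain can be swapped for methoxymethyl without a shift beyond the scatter. Nothing shown explains why the methoxy and methyl chains read alike or why the other two differ from them.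

From the compounds shown here alone, it remains open whether an oxygen placed further along the chain, as in a methoxyethyl group, would read like compound 4 or like compound 1. The compounds also leave open how a longer chain such as butyl, or an amine or a carboxylic acid on this chain, would read in this assay.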